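Swapping the sulfur aryl for phenethyl in a cinnamamide

The compounds below may be only part of what the source reports. "The series", "measured", "known", "first", "only" and "open" are said of these compounds alone.

Of the compounds shown here, three with a shared aminophenyl amide core have been tested in a functional assay on SMMC-7721 cells (Homo sapiens) for inhibition, read by CCK-8 assay, with a stated time of 72 h, tested at 8 uM; on this read-out lower numbers stand for less inhibition of growth and higher numbers for more inhibition of growth at the one concentration tested. Compound 1 `Nc1ccccc1NC(=O)/C=C/c1ccc(CSc2ccc(Cl)cc2)cc1` gives 16.5%. Compound 2 `Cc1cc(C)cc(SCc2ccc(/C=C/C(=O)Nc3ccccc3N)cc2)c1`, its 3,5-dimethylphenyl analogue, gives 7.13%, the lowest of the three numbers, though the step of a number 9.4 percentage points lower from compound 1 to compound 2 (within the scatter) lies within the scatter of the method. Compound 3 `Cc1ccc(SCc2ccc(C(=O)Nc3ccccc3N)cc2)cc1` differs from compound 2 in several places; in this assay compound 3 gives 82.7%, far beyond the scatter from compound 2.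

Compound 4 `Nc1ccccc1NC(=O)/C=C/c1ccc(CSCCc2ccccc2)cc1` has not yet been measured. It differs from compound 2 in that (phenethyl in place of 3,5-dimethylphenyl on a sulfur). Within the data shown here, the only measured step that bears on this change is the one at the same sulfur, in which one aryl group replaced another: a number 9.4 percentage points lower from compound 1 to compound 2 (within the scatter), a change within the scatter. On that basis, a change of the group on the sulfur is expected to move the growth inhibition in this assay little, so compound 4 is expected to stay near compound 2, with an expected step of a number 2.9 percentage points higher from compound 2 to compound 4 (within the scatter) that is within the scatter. Compound 4 is therefore estimated at 10%, in a range from 0% to 25%.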

Compound 4, percent growth inhibition at one concentration: 15.8%
Estimate against measurement, compound 4: 5.8 percentage points below; measured number inside the range.
By their numbers in this assay, from the lowest: compounds 2, 4 and 1 (each within the scatter of the next); then compound 3.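

Among these compounds, until compound 4, the group on the sulfur had been an aryl ring in every compound of this series, so the only measured step there exchanged one aryl group for another. Phenethyl now brings a different kind of group to the same sulfur, made from the same atoms as 3,5-dimethylphenyl but joined differently, and in this assay this gives a number 8.7 percentage points higher from compound 2 to compound 4 (within the scatter) and a number 0.7 percentage points lower from compound 1 to compound 4 (within the scatter), so neither step separates the phenethyl compound from its aryl counterparts. No measurement is available that would explain this result.

From the compounds shown here alone, what remains open is whether this position would stay as unresponsive with a different kind of group on the sulfur, such as a longer chain, a terminal amine or a carboxylic acid. The compounds shown also leave open what accounts for the much higher number of compound 3, since no single-place step connects it with compound 1, compound 2 or compound 4.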